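The source may hold more compounds than are shown below. What is called first, only, known or untested is meant among the compounds shown, and "the series" means these compounds.

Measured so far in an assay on CHO cells for displacement of a labelled ligand from adenosine receptor A1 (Homo sapiens), read by scintillation counting, tested at 1 uM; a lower number here means less inhibition, a higher number more inhibition at the concentration tested (going by the name of the read-out):
- compound 1 `CC(C)Cc1nc(N)c2nn(-c3ccccc3)cc2n1`: 49%
- compound 2 `Cc1cccc(Cc2nc(N)c3nn(-c4ccccc4)cc3n2)c1`: 41%

Among the measured compounds shown here, compound 2 has the lower of the two numbers, but the only step recorded, a number 8 percentage points lower from compound 1 to compound 2 (within the scatter), is small, so the two compounds cannot be ranked against each other. Compound 3 `Nc1nc(Cc2cccc(C(F)(F)F)c2)nc2cn(-c3ccccc3)nc12` is the next compound to be measured. It differs from compound 2 in one place: trifluoromethyl in place of methyl on an aromatic carbon. For the measured compounds named here, the one measured step is the only guide available, and it concerns a different exchange, the group on the saturated chain carbon rather than a group on the outer ring. It shows that a sizeable change at that end of the molecule left the read-out nearly unchanged. Going by the values given here, no measured compound carries a trifluoromethyl, so nothing shows how that group itself behaves here. On this basis compound 3 is expected to give a step of a number 1 percentage points higher from compound 2 to compound 3 (within the scatter), no more than the scatter. Compound 3 is therefore estimated at 42%, in the range 22% to 62%.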

Compound 3, a percentage reported as inhibition, at one concentration (the size of the read-out at that concentration, not a potency): 1%
Beside the measured number, compound 3's estimate is 41 percentage points above it, outside the stated range (below it).
By their numbers in this assay, from the lowest: compound 3; then compounds 2 and 1 (each within the scatter of the next).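

In this assay, the group on the outer ring proves to matter a great deal: trifluoromethyl in place of methyl on this aromatic carbon gives a step of a number 40 percentage points lower from compound 2 to compound 3 (beyond the scatter). The earlier exchange of isopropyl for 3-methylphenyl, a step of a number 8 percentage points lower from compound 1 to compound 2 (within the scatter), gave no readable difference, so the number does not stay level through every change at this end of the molecule, and one exchange on the ring can remove nearly all the inhibition seen in this assay. Nothing measured here accounts for this loss.

With only methyl and trifluoromethyl shown at this place, it remains open whether the loss is specific to trifluoromethyl or would also appear with a chlorine atom, a methoxy group or an amine. On these data alone, it is equally open whether trifluoromethyl would have the same effect elsewhere on the ring.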